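The source may report more compounds than this note shows. Statements on the series, on what has been measured and on what is new or still open speak of the compounds shown alone.

Measured compounds in a functional assay on HeLa cells (Homo sapiens) for cytotoxicity, read by WST assay, with a stated time of 48 h; on this read-out higher numbers stand for weaker inhibition and lower numbers for stronger inhibition:
Compound 1, `COC[C@H](C)[C@H](C)C(c1ccc(O)c(OC)c1)c1ccc(O)c(OC)c1`, gives 72000 nM.
Compound 2, `COC[C@H](C(C)C)C(c1ccc(O)c(OC)c1)c1ccc(O)c(OC)c1`, gives 76000 nM.
Compound 3, `COc1cc(C(c2ccc(O)c(OC)c2)[C@H](C)[C@H](C)CO)ccc1O`, gives only a limit of the assay, > 100000 nM.

Compound 1 holds the lowest of the two numbers, but the step of a 1.1-fold higher number from compound 1 to compound 2 (0.02 log units; within the scatter) is within the scatter, so compound 1 and compound 2 cannot be ranked. Compound 3 sits at the limit of > 100000 nM in this assay, at which 1 of the 3 values shown sits; the steps of an at least 1.3-fold higher number from compound 1 to compound 3 (0.14 log units; that floor lies within the scatter) and an at least 1.3-fold higher number from compound 2 to compound 3 (0.11 log units; that floor lies within the scatter) have floors within the scatter, so nothing is settled there either.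

The new compound 4, `CCCCC[C@H](C(C)C)C(c1ccc(O)c(OC)c1)c1ccc(O)c(OC)c1`, differs from compound 1 in one place: 1-isopropylhexyl in place of 2-(methoxymethyl)-1-methylpropyl on a saturated chain carbon bound to two aromatic carbons.

Of the measured steps, only the move from compound 1 to compound 2 and the move from compound 1 to compound 3 touch the same saturated chain carbon, and both stayed within the scatter. Neither removes the single hydrogen-bond acceptor altogether or lengthens the chain to a 1-isopropylhexyl group, so the change to compound 4 goes beyond what has been measured. With every measured step in this series flat, no step beyond the scatter is expected in this assay, in either direction; the estimated step is a 1.0-fold lower number from compound 1 to compound 4 (0.01 log units; within the scatter).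

The expected value for compound 4 is therefore 70000 nM, with a range from 30000 nM to 160000 nM.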

Compound 4, half-maximal inhibitory concentration: 9200 nM
For compound 4 the middle estimate is 7.6-fold (0.88 log units) above the measured one; the measured number lies below the stated range.
By their numbers in this assay, from the lowest: compound 4; then compounds 1 and 2 (each within the scatter of the next). At a limit, above all of these: compound 3.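

In this assay, for the compounds shown here, the group on the saturated chain carbon bound to two aromatic carbons now proves able to move the read-out, which the earlier compounds, all carrying an oxygen in this group, did not show: 1-isopropylhexyl gives a 7.8-fold lower number from compound 1 to compound 4 (0.89 log units; beyond the scatter) and an at least 10-fold lower number from compound 3 to compound 4 (1.03 log units; beyond the scatter). The closest comparison is butyl in place of methoxy on a saturated chain carbon, three bonds along the chain from two aromatic carbons, which gives an 8.3-fold lower number from compound 2 to compound 4 (0.92 log units; beyond the scatter) and so ties the change to that end of the group, with the isopropyl branch held constant. The step that starts from compound 3 is only a floor, and compound 3 stands at a limit of the assay: the limit of > 100000 nM in this assay, at which 1 of the 4 values shown sits.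

Butyl in place of methoxy changes both the chain and the presence of the oxygen, so these compounds cannot tell whether the lower number follows the added carbons or the loss of the ether oxygen. A plain propyl group, a longer chain such as octyl, or an amine in place of methoxy would help separate the two and show how far the trend extends.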